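Compound 3 After the Carbamoyl Swap

The compounds below may be only part of what the source reports. "The series", "measured", "known", "first", "only" and "open" are said of these compounds alone.

Of the compounds shown here, two have been measured in a functional assay on MDA-MB-468 cells (Homo sapiens) for inhibition, read by sulforhodamine B assay, with a stated time of 48 h, tested at 0.1 uM; on this read-out lower numbers stand for a stronger effect and higher numbers for a weaker effect at the one concentration tested. Compound 1 `O=C(Nc1cccc(-n2cc(-c3ccncc3)c(-c3cc(O)cc(Cl)c3)n2)c1)Nc1ccc(Cl)c(Cl)c1` gives 85% in this assay, and compound 2 `COc1cc(Cl)cc(-c2nn(-c3cccc(NC(=O)Nc4ccc(Cl)c(Cl)c4)c3)cc2-c2ccncc2)c1` gives 97%, the higher of the two numbers, separated by the step of a number 12 percentage points higher from compound 1 to compound 2 (beyond the scatter). Compound 3 `COc1cc(Cl)cc(-c2nn(-c3cccc(NC(=O)c4cccc(C(F)(F)F)c4)c3)cc2-c2ccncc2)c1` differs from compound 2 by 3-(trifluoromethyl)phenyl in place of (3,4-dichlorophenyl)amino on a carbonyl carbon. Within the data shown here, the only measured step, methyl in place of hydrogen on an oxygen, touches a different part of the molecule, so no measured step bears on this change. The step of a number 3 percentage points lower from compound 2 to compound 3 (within the scatter) is therefore expected to stay within the scatter. The estimate for compound 3 is 94%, expected between 74% and 106%.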

Compound 3, a percentage reported as activity, at one concentration (the size of the read-out at that concentration, not a potency): 85%
For compound 3 the middle estimate is 9 percentage points above the measured one; low and high end bracket the measured number.
By their numbers in this assay, from the lowest: compounds 1 and 3 (each within the scatter of the next); then compound 2.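

In this assay the carbonyl carbon proves to be a position where a change registers: with 3-(trifluoromethyl)phenyl in place of (3,4-dichlorophenyl)amino, the read-out shows a number 12 percentage points lower from compound 2 to compound 3 (beyond the scatter), towards a stronger effect. Among these compounds, the earlier compounds varied only a group on an oxygen, so this is the first reading on this side of the molecule. Among the compounds shown here, the swap also takes away the hydrogen-bond donor counted in the leaving group while changing the ring substituents, and the single step does not separate these. Going by these compounds, whether an amine or a carboxylic acid on the entering ring would hold or extend this shift stays open. Nothing available accounts for the size or direction of the step.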